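The source may report more compounds than this note shows. Statements on the series, on what has been measured and on what is new or still open speak of the compounds shown alone.

Measured compounds:
Compound 1, `C=CCOc1cc(OC)c(C(=O)/C=C/c2cc(OC)c(OC)c(OC)c2)c(OCC=C)c1`: in a toxicity assay on cells (Macrophage, Mus musculus, strain BALB/c) for cytotoxicity, read by MTT assay (on this read-out higher numbers stand for weaker inhibition and lower numbers for stronger inhibition), compound 1 gives 12000 nM.
Compound 2, `C=CCOc1cc(OC)c(C(=O)/C=C/c2ccncc2)c(OCC=C)c1`: in this assay compound 2 gives "not determined" (no result reported).

Only compound 1 carries a number in this assay, and it shows weak inhibition there. Compound 2 shares the core of compound 1 but carries a pyridin-4-yl group on the double-bonded chain carbon in place of the trimethoxyphenyl group; for compound 2 no result was reported in this assay, so it stands nowhere on the numbers shown and gives no anchor of its own.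

Compound 3, `C=CCOc1cc(OC)c(C(=O)/C=C/c2ccccn2)c(OCC=C)c1`, differs from compound 2 in one place: pyridin-2-yl in place of pyridin-4-yl on a double-bonded chain carbon bound to a double-bonded chain carbon. Because compound 2 has no value, the step from compound 2 to compound 3 cannot be sized from a measured pair. The change keeps the same atoms joined differently, and nothing in the shown data suggests that it should move cytotoxicity beyond the scatter in either direction; the expectation is therefore no step beyond the scatter, anchored instead on what compound 1 shows.

Compound 3 is expected to give about 15000 nM in this assay, with a range from 4000 nM to 60000 nM.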

Compound 3, half-maximal inhibitory concentration: 12500 nM
Beside the measured number, compound 3's estimate is 1.2-fold (0.08 log units) above it; measured number inside the range.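

With no number for compound 2 in this assay, the step from compound 2 to compound 3 cannot be read, and the value of compound 3 stands without a measured partner. Nothing shown offers an explanation for this result. The compounds shown leave open whether exchanging pyridin-4-yl for pyridin-2-yl shifts the read-out in this assay at all.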